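The source may report more compounds than this note shows. Statements on the series, on what has been measured and on what is new or still open speak of the compounds shown alone.

Measured so far in a functional assay on NCI-H522 cells (Homo sapiens) for cytotoxicity; on this read-out higher numbers stand for weaker inhibition of growth and lower numbers for stronger inhibition of growth:
Compound 1 `COc1ccc(/N=C/c2cc(OC)c(OC)c(OC)c2)cc1`: > 100000 nM (a limit)
Compound 2 `CCOc1ccc(/N=C/c2cc(OC)c(OC)c(OC)c2)cc1`: > 100000 nM (a limit)

In this assay compound 2 reads > 100000 nM as a limit of the assay and not a number. Compound 1 likewise gives > 100000 nM as a limit. Together they make up all that has been measured here (the limit of > 100000 nM in this assay, at which 2 of the 2 values shown sit).

Compound 3 `CCCc1ccc(/N=C/c2cc(OC)c(OC)c(OC)c2)cc1` carries a single structural change from compound 2: propyl in place of ethoxy on an aromatic carbon is the difference, with propyl in place of ethoxy on an aromatic carbon, para to a large group.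

Among the compounds with values here, only one measured step bears on this change, and it altered the same ethoxy group. That step is a step that the two limits leave unreadable from compound 1 to compound 2 and therefore offers no size to carry forward. Within the data shown here, no measured compound yet has propyl in this place, so the expectation is weakly founded. It is for little or no change in this assay and a reading at the same limit is the likeliest outcome. If a number does appear, it is expected on the side of stronger inhibition of growth.

The expected size is an at least 1.2-fold lower number from compound 2 to compound 3 (0.09 log units; that floor lies within the scatter) as an estimate only. For compound 3 the estimated value is 80000 nM with an expected range from 30000 nM to 100000 nM in this assay.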

Compound 3, concentration for 50% growth inhibition: > 100000 nM
Compound 3 gave a limit, no number (the forecaster's own chance of this, stated with the estimate: 70%); at least 1.2-fold (0.09 log units) between middle value and limit.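

In this assay compound 3 gives > 100000 nM, a limit of the assay and not a number. Within the data shown here, no step among compound 1, compound 2 and compound 3 can be read from these limits. The compounds shown leave open whether any of the three inhibits growth measurably and how they would rank against one another.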